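The source may hold more compounds than are shown below. What is called first, only, known or untested is meant among the compounds shown, and "the series" means these compounds.

In an ADME assay on a cell-free system (plasma, Homo sapiens) for metabolic stability, read by LC-MS (a higher number here means that the compound lasts longer, a lower number that the compound disappears faster), compound 1 (`CCCCCCOC(=O)c1cccc(-c2cc(C(=O)Nc3ccncc3)ccc2CN)c1`) gives a half-life of 0.833 h and stands within the scatter of compound 2 (`COC(=O)c1cccc(-c2cc(C(=O)Nc3ccncc3F)ccc2CN)c1`), which gives 1.08 h in the same measurement. Neither compound can be set apart from the other on these numbers.

Compound 3 (`CCCOC(=O)c1cccc(-c2cc(C(=O)Nc3ccncc3)ccc2CN)c1`) has not yet been measured. It keeps the core of compound 1 and differs from it in a single place (hydrogen in place of propyl on a saturated chain carbon, three bonds along the chain from an oxygen next to a carbonyl group), with hydrogen in place of propyl on a saturated chain carbon, three bonds along the chain from an oxygen next to a carbonyl group. The same difference reads hexyl to propyl.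

Among the compounds with values here, no step between measured compounds shows directly what such a change does, so the two values are the only guide. With compound 1 at 0.833 h and compound 2 at 1.08 h lying so close, no step beyond the scatter is expected in this assay, and no firm direction. The expected move (a 1.2-fold higher number from compound 1 to compound 3 (0.08 log units; within the scatter)) is correspondingly small. For compound 3 the estimated half-life is 1 h in a range from 0.45 h to 2.2 h as expected limits.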

Compound 3, half-life: 0.3 h
The estimate for compound 3 lay 3.3-fold (0.52 log units) above the measured number; the measured number lies below the stated range.
By their numbers in this assay, from the lowest: compound 3; then compounds 1 and 2 (each within the scatter of the next).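

Cutting the chain from hexyl to propyl, at the saturated chain carbon three bonds along the chain from an oxygen next to a carbonyl group, gives a 2.8-fold lower number from compound 1 to compound 3 (0.44 log units; beyond the scatter) in this assay and is the only step beyond the scatter among the compounds shown. The earlier values could not show this, and the pair now shows that the length of this chain is not indifferent on the core of compound 1: with everything else held the same, the propyl compound disappears faster than the hexyl compound, although the size of the step is modest. Nothing in the data offered here explains the step, and the result stands as an observation about this one pair.

With only hexyl and propyl compared on this core, two chain lengths cannot tell whether the number moves steadily along the chain or shifts at one particular length. From the compounds shown here alone, how a butyl or pentyl chain would fall between them stays open, as does what a methyl group or a branched chain such as isopropyl would give at the same place.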